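The source may report more compounds than this note shows. Statements on the series, on what has been measured and on what is new or still open speak of the compounds shown alone.

Compound 1 `Cc1cc(NCc2ccccn2)n2ncc(-c3ccc(C(F)(F)F)cc3)c2n1` gives < 5000 nM in a physicochemical assay for solubility, read by HPLC, using the shake flask method, measured as kinetic solubility, with a stated time of 2 h, at pH 7.4 (a higher number here means a more soluble compound, a lower number a less soluble compound), which is a limit of the assay and not a number.
Compound 2 `Cc1cc(NCc2ccccn2)n2ncc(-c3ccccc3C)c2n1` gives < 5000 nM in this assay, again a limit of the assay.
Compound 3 `Cc1cc(NCc2ccccn2)n2ncc(-c3ccc(F)cc3F)c2n1` gives < 5000 nM in this assay, again a limit of the assay.

Compound 3 therefore stands only at a limit in this assay, and the same holds for the other two values shown, as the limit of < 5000 nM in this assay, at which 3 of the 3 values shown sit, summarises. Going by the values given here, the one step between measured neighbours, a step that the two limits leave unreadable from compound 2 to compound 3, cannot be read in size or direction for the same reason.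

Compound 4 `Cc1cc(NCc2ccccn2)n2ncc(-c3ccc(O)cc3)c2n1` differs from compound 3 in one place: 4-hydroxyphenyl in place of 2,4-difluorophenyl on an aromatic carbon. Nothing measured here tells how large a step this change brings in this assay, since the only step shown, from one limit to another, is unreadable. The expectation for compound 4 rests on the 4-hydroxyphenyl carrying one hydrogen-bond donor and one hydrogen-bond acceptor where the 2,4-difluorophenyl carried none; the expected step of an at least 1.6-fold higher number from compound 3 to compound 4 (0.20 log units; that floor lies within the scatter) is toward higher solubility, but it may still end at a limit. Compound 4 is estimated at 8000 nM, within a range from 2000 nM to 40000 nM.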

Compound 4, solubility: 10900 nM
Compound 4: middle estimate off by 1.4-fold (0.13 log units), on the low side, within the range that was stated.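

Compound 4 is the only compound shown that gives a number rather than a limit in this assay, so a change on this aromatic carbon can now be sized, at least from one side: 4-hydroxyphenyl in place of 2,4-difluorophenyl gives an at least 2.1-fold higher number from compound 3 to compound 4 (0.33 log units; beyond the scatter). The other two changes point the same way, with 4-hydroxyphenyl in place of 2-methylphenyl giving an at least 2.1-fold higher number from compound 2 to compound 4 (0.33 log units; beyond the scatter) and hydroxy in place of trifluoromethyl giving an at least 2.1-fold higher number from compound 1 to compound 4 (0.33 log units; beyond the scatter). Each of these sizes is a floor and not a full measure: the limit of < 5000 nM in this assay, at which 3 of the 4 values shown sit.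

Going by these compounds, the full size of these steps stays open, and the steps among the three compounds at the limit cannot be read. On these data alone, it is also open whether a phenyl carrying an amine or a carboxylic acid on this carbon would give a number like that of compound 4.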